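Methyl in Place of Cyano: An Expected Antiproliferative Outcome

The source may report more compounds than this note shows. Statements on the series, on what has been measured and on what is new or still open speak of the compounds shown alone.

Compound 1 `N#Cc1ccc(NC(=S)N/N=C/c2ccc3ccccc3n2)cc1`: 23700 nM
Compound 2 `CC(C)c1cccc(C(C)C)c1NC(=S)N/N=C/c1ccc2ccccc2n1`: 23500 nM

In a functional assay on SGC-7901 cells (Homo sapiens) for antiproliferative activity, read by sulforhodamine B assay, with a stated time of 72 h (on this read-out lower numbers stand for stronger inhibition and higher numbers for weaker inhibition), compound 1 gives 23700 nM, the higher of the two numbers shown, while compound 2 gives 23500 nM, a gap within the scatter, so the two cannot be told apart. Compound 3 `Cc1ccc(NC(=S)N/N=C/c2ccc3ccccc3n2)cc1` differs from compound 1 in one place: methyl in place of cyano on an aromatic carbon. Among the measured compounds shown here, no measured pair shows this change, so the expectation rests on the two numbers alone, which sit at one level. The expected step of a 1.1-fold lower number from compound 1 to compound 3 (0.03 log units; within the scatter) is none beyond the scatter. Compound 3 is therefore estimated at 22000 nM, between 7000 nM and 70000 nM.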

Compound 3, half-maximal inhibitory concentration: 92900 nM
Compound 3: the middle estimate sits 4.2-fold (0.63 log units) below what was measured; the measured number lies above the stated range.
By their numbers in this assay, from the lowest: compounds 2 and 1 (each within the scatter of the next); then compound 3.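

Going from 4-cyanophenyl to 4-methylphenyl in this assay gives a 3.9-fold higher number from compound 1 to compound 3 (0.59 log units; beyond the scatter), a modest step, and it shows that this position, on an aromatic carbon para to a large group, is not indifferent to the group it carries. The earlier compounds shown here, which differ in more than one place, could not show this. Nothing measured here accounts for the step.

As far as these compounds go, whether an amine, a carboxylic acid or a longer chain at this position would give a lower or higher number remains open. So does whether a chlorine atom or a methoxy group would stay closer to cyano or to methyl.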